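This account rests on a few compounds, and the source may have more. Where it says the series, first, only, none or still open, it means among the compounds named here.

Among the measured compounds shown here, compound 1 `O=C(NCCCCCCS)c1cc(-c2ccc(-c3ccccc3)cc2)n[nH]1` is the one member of this small set for which a number is in hand: in an assay on isolated protein for inhibition of protein deacetylase HDAC6 (Homo sapiens), read by fluorescence, with stated times of 15 min and 60 min (on this read-out lower numbers stand for stronger inhibition and higher numbers for weaker inhibition), compound 1 gives 106 nM. Compound 2 `Cc1cc(C(=O)NCCCCCCS)[nH]n1` shares the thiol-bearing chain and the amide with compound 1 but carries a methyl group on the shared core in place of the large group of compound 1; in this assay compound 2 gives "not determined" (no result reported), so no single number stands for compound 2, and it cannot be placed against compound 1.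

Compound 3 `O=C(NCCCCCCS)c1ccn[nH]1` is reached from compound 2 by a single change: hydrogen in place of methyl on an aromatic carbon. For the measured compounds named here, with no measured pair of this kind, the size of such a step can only be guessed; it is expected to fall within the usual scatter, in either direction, since the change removes a single carbon from the core.

Taking compound 1 as the sole anchor, and noting that compound 3 keeps the chain and amide of compound 1 but lacks its large group, compound 3 is expected to give about 500 nM in this assay, estimated to fall between 120 nM and 3000 nM.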

Compound 3, half-maximal inhibitory concentration: 92 nM
Beside the measured number, compound 3's estimate is 5.4-fold (0.74 log units) above it; the measured number lies below the stated range.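

The step between compound 2 and compound 3 cannot be read: in this assay compound 2 has no single number. The compounds shown leave open what swapping methyl for hydrogen on the shared core does to this read-out. Nothing shown here bears on the cause of the value of compound 3.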